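Two bromines on the aminophenyl sulfonamide at the serotonin receptor

The source may hold more compounds than are shown below. What is called first, only, known or untested is meant among the compounds shown, and "the series" means these compounds.

Measured so far:
compound 1 `COc1cc(N)c(Cl)cc1C(=O)CCC1CCN(CCNS(=O)(=O)c2ccc(N)c(Br)c2)CC1`: 85%
compound 2 `COc1cc(N)c(Cl)cc1C(=O)CCC1CCN(CCNS(=O)(=O)c2ccc(N)cc2)CC1`: 46%

In an assay on HEK293 cells for displacement of a labelled ligand from 5-hydroxytryptamine receptor 6 (Homo sapiens), with a stated time of 60 min, tested at 1 uM, in the presence of a further agent that is not named here (on this read-out higher numbers stand for a stronger effect at the one concentration tested and lower numbers for a weaker effect), compound 2 gives 46%, the lowest of the two numbers recorded so far; its nearest neighbour is compound 1, which gives 85%. Compound 3 `COc1cc(N)c(Cl)cc1C(=O)CCC1CCN(CCNS(=O)(=O)c2cc(Br)c(N)c(Br)c2)CC1` has not yet been measured. It differs from compound 2 in one place: 4-amino-3,5-dibromophenyl in place of 4-aminophenyl on a sulfonyl sulfur.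

Among the compounds with values here, the one measured step that bears on this change is the step between compound 1 and compound 2, in which hydrogen replaces bromo on an aromatic carbon: a number 39 percentage points lower from compound 1 to compound 2 (beyond the scatter). Compound 3 reverses that change and adds a second bromo on the same ring, so a step in the opposite direction, back up towards the number of compound 1, is expected. Because the step of a number 39 percentage points lower from compound 1 to compound 2 (beyond the scatter) was large, the expected step of a number 39 percentage points higher from compound 2 to compound 3 (beyond the scatter) is also large and upward. Compound 3 is therefore estimated to give 85%, within a range from 65% to 98%.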

Compound 3, a percentage reported as inhibition, at one concentration (the size of the read-out at that concentration, not a potency): 83%
Compound 3: middle estimate off by 2 percentage points, on the high side; the measured number falls inside the stated range.
By their numbers in this assay, from the lowest: compound 2; then compounds 3 and 1 (each within the scatter of the next).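

In this assay, putting 4-amino-3,5-dibromophenyl in place of 4-aminophenyl on the sulfonyl sulfur gives a number 37 percentage points higher from compound 2 to compound 3 (beyond the scatter), a large step that shows the ring carrying two bromo groups keeps the gain seen with one. The second bromo adds nothing that can be read, however: the step is a number 2 percentage points lower from compound 1 to compound 3 (within the scatter), so among these three compounds the gain comes with the first bromo and does not grow with the second, and the second is tolerated without a visible loss. No measurement shown here accounts for this levelling off.

The read-out at one concentration leaves open whether compound 1 and compound 3 would also match in a full measurement of potency, which could separate two compounds that look alike here. From the compounds shown here alone, it also remains open whether the effect belongs to bromo itself or would also appear with chloro, iodo or methyl on the same ring, and whether the amino group on that ring could be exchanged for a hydroxyl group without changing the number.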